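The source may report more compounds than this note shows. Statements on the series, on what has been measured and on what is new or still open speak of the compounds shown alone.

Measured so far in an assay on isolated protein for displacement of a labelled ligand from metabotropic glutamate receptor 5 (Homo sapiens), with a stated time of 60 min, tested at 1 uM; a higher number here means more inhibition at the concentration tested (going by the name of the read-out), a lower number less inhibition:
compound 1 `CC1CCN(c2c(S(=O)(=O)c3ccc(F)cc3)cnc3ccc(Cl)cc23)CC1` gives 89%
compound 2 `COc1ccc2ncc(S(=O)(=O)c3ccc(F)cc3)c(N3CCC(C)CC3)c2c1` gives 27%

Compound 1 stands highest of the two numbers. Going by the values given here, the only measured step, a number 62 percentage points lower from compound 1 to compound 2 (beyond the scatter), is beyond the scatter, but it concerns methoxy in place of chloro on an aromatic carbon and not the sulfonyl substituent. Compound 3 `CC1CCN(c2c(S(=O)(=O)c3cc(F)cc(F)c3)cnc3ccc(Cl)cc23)CC1` differs from compound 1 by 3,5-difluorophenyl in place of 4-fluorophenyl on a sulfonyl sulfur. Among the compounds with values here, no measured step touches that position, so nothing bears directly on this change. The step expected in this assay is a number 9 percentage points lower from compound 1 to compound 3 (within the scatter), not beyond the scatter. Compound 3 is therefore estimated at 80%, with a range of 55% to 95%.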

Compound 3, a percentage reported as inhibition, at one concentration (the size of the read-out at that concentration, not a potency): 93%
Compound 3: the middle estimate sits 13 percentage points below what was measured, within the range that was stated.
By their numbers in this assay, from the lowest: compound 2; then compounds 1 and 3 (each within the scatter of the next).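

Going by these compounds alone, on the sulfonyl sulfur, 3,5-difluorophenyl in place of 4-fluorophenyl gives a number 4 percentage points higher from compound 1 to compound 3 (within the scatter) in this assay and provides the first reading at this position. The second fluorine is accepted here, with the inhibition holding as high as in compound 1. No evidence on the cause accompanies this result.

From the compounds shown here alone, whether this position accepts anything other than a fluorinated phenyl, such as a pyridyl ring or a plain methyl, stays open. Readings this close at a single concentration also leave open any ordering of potency between compound 1 and compound 3.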